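Swapping One Aromatic Group on a Shared Core

A few compounds are considered here, and "the series" means these few. Any claim that something is new, unique, unknown or untested is made for them only; others in the source may bear on it.

In a physicochemical assay for solubility, at pH 7.4 (a lower number here means a less soluble compound, a higher number a more soluble compound), compound 1 (`CSc1ccc(NC(=O)Nc2cc(C)nc3ccccc23)cc1`) gives 1300 nM. Compound 2 (`Cc1cc(NC(=O)Nc2ccccc2N)c2ccccc2n1`) gives 51800 nM, the higher of the two numbers, and the gap between them lies beyond the usual scatter of repeated measurements. Compound 3 (`Cc1ccc(NC(=O)Nc2cc(C)nc3ccccc23)cc1`) has not yet been measured. It differs from compound 2 in one place, with 4-methylphenyl in place of 2-aminophenyl on an amide-type nitrogen. Among the measured compounds shown here, no measured pair shows this kind of swap directly, so any forecast is a judgement. In structure, compound 3 looks closer to compound 1, which stands at 1300 nM, than to compound 2. A large downward step, beyond the scatter, is therefore expected in this assay. The estimated change is a 26-fold lower number from compound 2 to compound 3 (1.41 log units; beyond the scatter). For compound 3 the expected value is 2000 nM, with an estimated range of 500 nM to 8000 nM.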

Compound 3, solubility: 1300 nM
Compound 3: middle estimate off by 1.5-fold (0.19 log units), on the high side, within the range that was stated.
By their numbers in this assay, from the lowest: compounds 1 and 3 (each within the scatter of the next); then compound 2.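

In this assay, 4-methylphenyl in place of 2-aminophenyl on an amide-type nitrogen gives a 40-fold lower number from compound 2 to compound 3 (1.60 log units; beyond the scatter), so a single swap of the aromatic group at this position can carry a large step. By contrast, methyl in place of methylsulfanyl on an aromatic carbon gives no change at the digits printed from compound 1 to compound 3 (within the scatter), so this pair shows a swap on that ring that leaves the read-out within the scatter. No measurement on hand explains why the first swap has so much larger a step than the second.

The large step swaps two whole groups, so the compounds shown cannot separate the loss of the amine from the shift in where the ring carries its substituent. On these data alone, it also remains open whether 4-aminophenyl, or a phenyl ring carrying a carboxylic acid, would give a value nearer that of compound 2 or that of compound 3.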